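A few compounds are considered here, and "the series" means these few. Any claim that something is new, unique, unknown or untested is made for them only; others in the source may bear on it.

Measured compounds:
compound 1 `COc1cc(N(C)C)c(NC(=O)c2ccncc2OC)cc1Nc1nccc(-c2cn(C)c3ccccc23)n1`, 3030 nM
compound 2 `COc1cc(N(C)C)c(NC(=O)c2ncccn2)cc1Nc1nccc(-c2cn(C)c3ccccc23)n1`, 8640 nM
compound 3 `COc1cc(N(C)C)c(NC(=O)c2ccnc(Cl)n2)cc1Nc1nccc(-c2cn(C)c3ccccc23)n1`, 2840 nM

In a functional assay on A549 cells (Homo sapiens) for antiproliferative activity, read by MTT assay, with a stated time of 72 h (a higher number here means a weaker inhibitor, a lower number a stronger inhibitor), compound 3 gives the lowest of the three numbers. Its nearest neighbour is compound 1: a 1.1-fold lower number from compound 1 to compound 3 (0.03 log units; within the scatter), which places the two within the scatter of each other. Compound 2 stands apart: a 3.0-fold lower number from compound 2 to compound 3 (0.48 log units; beyond the scatter).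

Compound 4 `COc1cc(N(C)C)c(NC(=O)c2nccn2C)cc1Nc1nccc(-c2cn(C)c3ccccc23)n1` differs from compound 3 in one place: 1-methyl-1H-imidazol-2-yl in place of 2-chloropyrimidin-4-yl on a carbonyl carbon. The shared core and the amide linkage stay the same.

Within the data shown here, two measured steps bear on this change, both swapping the aromatic group on the carbonyl carbon. The first, a 2.9-fold higher number from compound 1 to compound 2 (0.46 log units; beyond the scatter), and the second, a 3.0-fold lower number from compound 2 to compound 3 (0.48 log units; beyond the scatter), show that such swaps have moved this assay by modest amounts in either direction, while the swap from compound 1 to compound 3 left the number essentially unchanged. Among the measured compounds shown here, none of the measured groups is a five-membered ring, so the data give no direct precedent for the 1-methyl-1H-imidazol-2-yl group.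

On this basis compound 4 is expected to stay close to compound 3, with a step of a 1.4-fold higher number from compound 3 to compound 4 (0.15 log units; within the scatter), most likely within the scatter. The estimate for compound 4 in this assay is 4000 nM, with a range from 1500 nM to 12000 nM.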

Compound 4, half-maximal inhibitory concentration: 10200 nM
The estimate for compound 4 lay 2.6-fold (0.41 log units) below the measured number, within the range that was stated.
By their numbers in this assay, from the lowest: compounds 3 and 1 (each within the scatter of the next); then compounds 2 and 4 (each within the scatter of the next).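

With the 1-methyl-1H-imidazol-2-yl group, a five-membered ring stands on the carbonyl carbon for the first time among these compounds, and in this assay it does not stay with the two lowest numbers (a 3.6-fold higher number from compound 3 to compound 4 (0.56 log units; beyond the scatter); a 3.4-fold higher number from compound 1 to compound 4 (0.53 log units; beyond the scatter)), with both steps beyond the scatter. It falls instead within the scatter of the pyrimidin-2-yl amide (a 1.2-fold higher number from compound 2 to compound 4 (0.07 log units; within the scatter)), so the four compounds form two pairs, compounds 3 and 1 with the lower numbers and compounds 2 and 4 with the higher, and each ring size is found in the higher pair, which means that ring size alone does not sort these compounds. No measurement offered here explains why the group on the carbonyl carbon moves the number in this way.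

As far as these compounds go, it remains open whether the 1-methyl group or the imidazole ring itself goes with the higher number, and whether an unsubstituted imidazol-2-yl, a phenyl or a simple aliphatic amine on the carbonyl carbon would join the lower pair or the higher one. From the compounds shown here alone, whether the same order of groups holds in any other cell line also stays open.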